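The source may report more compounds than this note shows. Statements on the series, on what has been measured and on what is new or still open speak of the compounds shown alone.

Compound 1 `O=C(c1ccccc1)c1sc(N2CCN(c3ccccc3)CC2)nc1-c1ccccc1` gives 38.3% in an assay for inhibition of Polyunsaturated fatty acid 5-lipoxygenase (Homo sapiens), read by spectrophotometry, tested at 10 uM; a lower number here means less inhibition, a higher number more inhibition at the concentration tested (going by the name of the read-out); compound 2 `O=C(c1ccccc1)c1sc(N(c2ccccc2)c2ccccc2)nc1-c1ccccc1` gives 48.6%; compound 3 `COc1ccc(-c2nc(N3CCN(c4ccccc4)CC3)sc2C(=O)c2ccccc2)cc1` gives 53.1%.

Among these three, compound 2 stands second highest: its nearest neighbour, compound 3, lies within the scatter, while compound 1 lies beyond the scatter below it. Compound 4 `COc1ccc(-c2nc(N(c3ccccc3)c3ccccc3)sc2C(=O)c2ccccc2)cc1` differs from compound 2 in one place: methoxy in place of hydrogen on an aromatic carbon. Within the data shown here, one measured step bears on this change, the same methoxy in place of hydrogen on the core of compound 1, which gave a number 14.8 percentage points higher from compound 1 to compound 3 (beyond the scatter), a modest rise beyond the scatter. A step of similar size and direction in this assay is therefore expected for compound 4, namely a number 11.4 percentage points higher from compound 2 to compound 4 (beyond the scatter). Compound 4 is estimated at 60%, expected to fall between 48% and 72%.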

Compound 4, a percentage reported as inhibition, at one concentration (the size of the read-out at that concentration, not a potency): 92.8%
For compound 4 the middle estimate is 32.8 percentage points below the measured one; the measured number lies above the stated range.
By their numbers in this assay, from the lowest: compound 1; then compounds 2 and 3 (each within the scatter of the next); then compound 4.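

In this assay, methoxy in place of hydrogen, para to a large group, gives a number 44.2 percentage points higher from compound 2 to compound 4 (beyond the scatter), a large step. The size of this change therefore does not carry over from one core to the other: the same change on two cores in this assay, a number 14.8 percentage points higher (beyond the scatter) from compound 1 to compound 3 and a number 44.2 percentage points higher (beyond the scatter) from compound 2 to compound 4, 29.4 percentage points apart, beyond the scatter of two such steps

The compounds shown leave open whether a hydroxyl, a fluorine or a longer ethoxy chain in the same place would match methoxy, and how the step would run on further cores. Read at one concentration, these numbers also give no potency for compound 4.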